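This account rests on a few compounds, and the source may have more. Where it says the series, first, only, none or still open, it means among the compounds named here.

Compound 1 `COc1ccc(C(=O)/C=C/c2cc(-c3cc(OC)c(OC)c(OC)c3)n[nH]2)cc1OC` — 1820 nM
Compound 2 `COc1ccc(C(=O)/C=C/c2cc(-c3cc(OC)c(OC)c(OC)c3)n[nH]2)cc1` — 1990 nM

For the measured compounds named here, in a functional assay on SF-268 cells (Homo sapiens) for inhibition, read by sulforhodamine B assay, with a stated time of 48 h (a higher number here means a weaker inhibitor of growth, a lower number a stronger inhibitor of growth), compound 2 has the higher of the two numbers, but the only measured step, a 1.1-fold higher number from compound 1 to compound 2 (0.04 log units; within the scatter), lies within the scatter, so the two compounds cannot be ordered. Compound 3 `COc1cc(-c2cc(/C=C/C(=O)c3ccc(F)c(F)c3)[nH]n2)cc(OC)c1OC` is not yet measured; it differs from compound 2 by 3,4-difluorophenyl in place of 4-methoxyphenyl on a carbonyl carbon. Going by the values given here, that one measured step alters the same ring and was within the scatter; no measured pair tests fluorine entering that ring. A step of about the scatter is therefore expected, a 1.0-fold higher number from compound 2 to compound 3 (0.00 log units; within the scatter), in no firm direction. Compound 3 is estimated at 2000 nM, between 700 nM and 6000 nM.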

Compound 3, concentration for 50% growth inhibition: 3150 nM
For compound 3 the middle estimate is 1.6-fold (0.20 log units) below the measured one; measured number inside the range.
By their numbers in this assay, from the lowest: compounds 1, 2 and 3 (each within the scatter of the next).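

On the carbonyl carbon, 3,4-difluorophenyl is the only ring shown without a methoxy group, and in this assay the change stays within the scatter: a 1.6-fold higher number from compound 2 to compound 3 (0.20 log units; within the scatter), and a 1.7-fold higher number from compound 1 to compound 3 (0.24 log units; within the scatter). Methoxy on this ring is therefore not shown to be required for growth inhibition in this series. No supporting data explain these steps.

On these data alone, whether an amine or a carboxylic acid on this ring would move the number beyond the scatter remains open. As far as these compounds go, the effect of replacing the ring with a saturated cyclohexyl group also remains open.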